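Swapping a Fluorophenyl for a Dimethoxyphenyl on the Core

This account rests on a few compounds, and the source may have more. Where it says the series, first, only, none or still open, it means among the compounds named here.

Compound 3 `CC(C(=O)NCc1ccc(C(F)(F)F)cc1-c1cccc(F)c1)c1ccc(NS(C)(=O)=O)c(F)c1` belongs to a small set of three amides built on one shared core, differing only in the group attached to one aromatic carbon of that core. In an assay on CHO cells for antagonist activity at transient receptor potential cation channel subfamily V member 1 (Homo sapiens), read by FLIPR (on this read-out lower numbers stand for stronger inhibition and higher numbers for weaker inhibition), compound 3 gives 1.9 nM. Compound 1 `CCCCCCSc1cc(C(F)(F)F)ccc1CNC(=O)C(C)c1ccc(NS(C)(=O)=O)c(F)c1` gives 1.8 nM and compound 2 `CC(C(=O)NCc1ccc(C(F)(F)F)cc1SCc1ccco1)c1ccc(NS(C)(=O)=O)c(F)c1` gives 3.2 nM in this assay, so the three numbers lie close together: the step of a 1.1-fold higher number from compound 1 to compound 3 (0.02 log units; within the scatter) and the step of a 1.7-fold lower number from compound 2 to compound 3 (0.23 log units; within the scatter) are both within the scatter, as is a 1.8-fold higher number from compound 1 to compound 2 (0.25 log units; within the scatter). Compound 3 sits second highest of the three, but the spread is too small to tell the compounds apart.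

Compound 4 `COc1cc(OC)cc(-c2cc(C(F)(F)F)ccc2CNC(=O)C(C)c2ccc(NS(C)(=O)=O)c(F)c2)c1` has not been measured. It differs from compound 3 by 3,5-dimethoxyphenyl in place of 3-fluorophenyl on an aromatic carbon. The earlier exchanges at this same carbon, from a hexylsulfanyl to a furanylmethylsulfanyl to a fluorophenyl group, moved the numbers little, so a further swap there is expected to change little as well. The expected step of a 1.4-fold higher number from compound 3 to compound 4 (0.14 log units; within the scatter) is small. Compound 4 is therefore estimated at 2.6 nM, with a range from 1 nM to 7 nM.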

Compound 4, inhibition constant: 5.8 nM
For compound 4 the middle estimate is 2.2-fold (0.35 log units) below the measured one; the range from low to high includes it.
By their numbers in this assay, from the lowest: compounds 1, 3, 2 and 4 (each within the scatter of the next, the first and the last beyond it).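

Within the data shown here, at this aromatic carbon, the earlier exchanges all stayed within the scatter, whereas in this assay 3,5-dimethoxyphenyl gives the first steps beyond it, both modest (a 3.1-fold higher number from compound 3 to compound 4 (0.48 log units; beyond the scatter) and a 3.2-fold higher number from compound 1 to compound 4 (0.51 log units; beyond the scatter)), though not against the furanylmethylsulfanyl compound (a 1.8-fold higher number from compound 2 to compound 4 (0.26 log units; within the scatter)). The position is therefore not wholly indifferent to its substituent: replacing one substituted phenyl ring with another can move the number measurably, if only modestly. No measurement at hand explains this shift.

The compounds shown do not separate the effect of having one methoxy group from that of having two, which a 3-methoxyphenyl group could address. As far as these compounds go, how this carbon responds to a phenyl ring carrying an amine or a carboxylic acid also remains open.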